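Methoxy to methyl on two related cores

A few compounds are considered here, and "the series" means these few. Any claim that something is new, unique, unknown or untested is made for them only; others in the source may bear on it.

Of the compounds shown here, three have been measured. Compound 1 `CCC(COC)N(C)c1nc(C)nc2c1nnn2-c1ccc(C(C)C)cc1Br` gives 11.2 nM in an in vitro assay on 293-EBNA cells for binding affinity to corticotropin-releasing factor receptor 1 (Homo sapiens); a lower number here means a stronger inhibitor, a higher number a weaker inhibitor. Compound 2 `COCC(COC)N(C)c1nc(C)nc2c1nnn2-c1ccc(C(C)C)cc1Br` gives 21.3 nM in this assay, and compound 3 `CCC(COC)Oc1nc(C)nc2c1ncn2-c1ccc(C(C)C)cc1Br` gives 9.7 nM. Compound 3 and compound 1 lie within the scatter of each other; compound 3 against compound 2 is beyond it.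

Compound 2 and compound 1 differ in one place: methyl in place of methoxy on a saturated chain carbon, two bonds along the chain from a nitrogen on an aromatic ring The effect is a 1.9-fold lower number from compound 2 to compound 1 (0.28 log units; within the scatter).

Compound 4 `CCC(CC)Oc1nc(C)nc2c1ncn2-c1ccc(C(C)C)cc1Br` has not been measured. Going by the values given here, it differs from compound 3 in one place: methyl in place of methoxy on a saturated chain carbon, two bonds along the chain from an oxygen on an aromatic ring This is the same kind of change as the one from compound 2 to compound 1, but not the same: in the earlier pair the carbon sits two bonds along the chain from a nitrogen on an aromatic ring, here it sits two bonds along the chain from an oxygen on an aromatic ring. The difference between the two cores, that of compound 2 and that of compound 3, is not broken down here.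

Among the compounds with values here, the one precedent is a small step, within the scatter, so compound 4 is expected to land close to compound 3, with a step estimated at a 1.5-fold lower number from compound 3 to compound 4 (0.17 log units; within the scatter), resting on compound 3 at 9.7 nM and on the earlier step of a 1.9-fold lower number from compound 2 to compound 1 (0.28 log units; within the scatter). Compound 4 is therefore estimated at 6.5 nM, with a range from 3 nM to 15 nM.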

Compound 4, inhibition constant: 3.5 nM
For compound 4 the middle estimate is 1.9-fold (0.27 log units) above the measured one, within the range that was stated.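

In this assay, methyl in place of methoxy on a saturated chain carbon, two bonds along the chain from an oxygen on an aromatic ring, gives a 2.8-fold lower number from compound 3 to compound 4 (0.44 log units; beyond the scatter). Both steps with this change run in the same direction, and although only the newer one lies beyond the scatter, the gap between them is small enough that the two cores cannot be told apart in their response to it: the same change on two cores in this assay, a 1.9-fold lower number (0.28 log units; within the scatter) from compound 2 to compound 1 and a 2.8-fold lower number (0.44 log units; beyond the scatter) from compound 3 to compound 4, 1.5-fold (0.16 log units) apart, within the scatter of two such steps This supports carrying the change from one core to the other within these two pairs, but it rests on just those pairs, and it does not show that the change would behave alike on any further core or separate the part played by the core from that of the nitrogen or oxygen carrying the chain.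

What remains open is how a pentan-3-yl group would behave on the core of compound 1, where a methoxymethyl group is still present in every compound shown. As far as these compounds go, it is also open whether a hydroxyl, a fluorine or a longer chain in place of the methoxy would follow the same trend on either core.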